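Swapping Ethynyl for Cyano on a Phenyl Ring

The source may report more compounds than this note shows. Statements on the series, on what has been measured and on what is new or still open speak of the compounds shown alone.

Three compounds with a shared core were tested in an assay on isolated protein for inhibition of retinal dehydrogenase 2 (Homo sapiens); on this read-out lower numbers stand for stronger inhibition and higher numbers for weaker inhibition. Compound 1 `Cn1ncc2c(=O)n(-c3ccccc3)c(SCc3cccc(F)c3)cc21` gives 240 nM and compound 2 `CCC(Sc1nc2c(cnn2C)c(=O)n1-c1ccccc1)c1ccccc1` gives 179 nM. Compound 3 `C#Cc1ccc(-n2c(SC(C)c3ccccc3)nc3c(cnn3C)c2=O)cc1` gives 800 nM, the highest of the three numbers, beyond the usual scatter from both others, so it is the weakest inhibitor among them. Compound 4 `CC(Sc1nc2c(cnn2C)c(=O)n1-c1ccc(C#N)cc1)c1ccccc1` has not been measured. It differs from compound 3 in one place: cyano in place of ethynyl on an aromatic carbon. Within the data shown here, no measured pair shows this exchange, so its effect is unknown; only a modest step is expected, within the scatter or just beyond it. Compound 4 is expected to give about 600 nM, with a range from 250 nM to 1500 nM. The expected step of a 1.3-fold lower number from compound 3 to compound 4 (0.12 log units; within the scatter) is a slight gain.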

Compound 4, half-maximal inhibitory concentration: 3100 nM
Estimate against measurement, compound 4: 5.2-fold (0.71 log units) below, and the stated range ends below it.
By their numbers in this assay, from the lowest: compounds 2 and 1 (each within the scatter of the next); then compound 3; then compound 4.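

Cyano in place of ethynyl gives a 3.9-fold higher number from compound 3 to compound 4 (0.59 log units; beyond the scatter), which means weaker inhibition, although both groups have the same number of heavy atoms and each holds one triple bond. This shows that the group on this aromatic carbon matters, and that even a small exchange can shift the number beyond the scatter. Nothing available explains the loss.

Still open, going by these compounds, is how other groups would behave at this place, such as an amine, a carboxylic acid or a longer chain. It is also unknown whether this exchange would have the same effect on a different core.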